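Branching the acyl chain in the acetonide sugar amides

The source may report more compounds than this note shows. Statements on the series, on what has been measured and on what is new or still open speak of the compounds shown alone.

Three amides of the shared core, differing only in the acyl chain, have been measured. In a functional assay on K562 cells (Homo sapiens) for antiproliferative activity (on this read-out higher numbers stand for weaker inhibition and lower numbers for stronger inhibition), compound 1 `CCC(=O)N[C@@H]1[C@H]2OC(C)(C)O[C@H]2O[C@@H]1[C@H](O)CO` gives 30000000 nM, compound 2 `CCCC(=O)N[C@@H]1[C@H]2OC(C)(C)O[C@H]2O[C@@H]1[C@H](O)CO` gives 500000 nM and compound 3 `CCCCCC(=O)N[C@@H]1[C@H]2OC(C)(C)O[C@H]2O[C@@H]1[C@H](O)CO` gives 10000000 nM. Compound 3 thus stands second highest of the three: its nearest neighbour is compound 1, and the widest gap is to compound 2, as the steps of a 3.0-fold lower number from compound 1 to compound 3 (0.48 log units; beyond the scatter) and a 20-fold higher number from compound 2 to compound 3 (1.30 log units; beyond the scatter) show; the remaining step is a 60-fold lower number from compound 1 to compound 2 (1.78 log units; beyond the scatter). All three steps lengthen the chain and none rearranges it.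

Compound 4 `CC(C)(C)CC(=O)N[C@@H]1[C@H]2OC(C)(C)O[C@H]2O[C@@H]1[C@H](O)CO` differs from compound 3 by tert-butyl in place of butyl on a saturated chain carbon bound to a carbonyl carbon. Among the compounds with values here, no measured step bears directly on such a rearrangement; the chain-length steps only show that the read-out moves without a simple trend across compound 1, compound 2 and compound 3. Within the data shown here, with no precedent for branching, the expected step of a 1.7-fold lower number from compound 3 to compound 4 (0.22 log units; within the scatter) lies within the scatter. Compound 4 is therefore estimated at 6000000 nM in this assay, with a range from 1000000 nM to 30000000 nM.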

Compound 4, half-maximal inhibitory concentration: 5000000 nM
Compound 4: middle estimate off by 1.2-fold (0.08 log units), on the high side, within the range that was stated.
By their numbers in this assay, from the lowest: compound 2; then compounds 4 and 3 (each within the scatter of the next); then compound 1.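

In this assay, moving from pentyl to neopentyl at this position, with the same atoms joined differently, gives a 2.0-fold lower number from compound 3 to compound 4 (0.30 log units; within the scatter) and so shows no separation between this branched chain and its straight isomer. The other two steps place the only branched chain in the series with respect to the shorter amides: a 10-fold higher number from compound 2 to compound 4 (1.00 log units; beyond the scatter) keeps compound 2 clearly apart from it, while a 6.0-fold lower number from compound 1 to compound 4 (0.78 log units; beyond the scatter) shows that compound 1 also stays apart from it. No supporting data bear on the reason for these numbers.

On these data alone, whether other branched chains such as isopropyl or isobutyl would follow compound 4 or compound 2 remains open. Also open, as far as these compounds go, is how a longer straight chain, a terminal amine or a carboxylic acid on the acyl chain would read out on the shared core.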